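Phenoxy for Fluorobenzyloxy: Expected Half-life in Dog Microsomes

The source may hold more compounds than are shown below. What is called first, only, known or untested is meant among the compounds shown, and "the series" means these compounds.

Two compounds of a shared core have been run in an in vitro ADME assay on microsomes from liver (Canis lupus familiaris) for metabolic stability, tested at 5 uM; a lower number here means that the compound disappears faster, a higher number that the compound lasts longer. Compound 1 `C=CC(=O)NCc1coc(-c2c(N)ncnc2Nc2ccc(OCc3ccccn3)c(F)c2)n1` gives 0.733 h in this assay. For compound 2 `C=CC(=O)NCc1coc(-c2c(N)ncnc2Nc2ccc(OCc3cccc(F)c3)c(Cl)c2)n1` this assay reports only a limit, > 1.66 h, so its half-life is known as a range rather than a number (the limit of > 1.66 h in this assay, at which 1 of the 2 values shown sits). Compound 3 `C=CC(=O)NCc1coc(-c2c(N)ncnc2Nc2ccc(Oc3ccccc3)c(Cl)c2)n1` differs from compound 2 by phenyl in place of 3-fluorobenzyl on an oxygen on an aromatic ring. No measured step of this kind exists among these compounds, so the expected change is small, an at least 1.1-fold lower number from compound 2 to compound 3 (0.04 log units; that floor lies within the scatter), no larger than the usual scatter. Compound 3 is therefore estimated at 1.5 h, within a range from 0.6 h to 3.5 h.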

Compound 3, half-life: > 1.66 h
Compound 3 was reported as a limit; the forecaster's own chance of this, stated with the estimate: 45%; at least 1.1-fold (0.04 log units) between middle value and limit.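

Compound 2 and compound 3 both stand at a limit in this assay, so no step can be read between them: the limit of > 1.66 h in this assay, at which 2 of the 3 values shown sit.

As far as these compounds go, whether phenyl or 3-fluorobenzyl on that oxygen gives the longer half-life stays open.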